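Replacing the nitrophenylhydrazone of compound 3 with an oxime

A few compounds are considered here, and "the series" means these few. Any claim that something is new, unique, unknown or untested is made for them only; others in the source may bear on it.

Compound 3 `O=c1cc(/C=N\Nc2ccc([N+](=O)[O-])cc2)c2ccc(OCc3ccccc3)cc2o1` carries a (4-nitrophenyl)amino group on a double-bonded nitrogen of the shared core. In a functional assay, read by spectrophotometry, with a stated time of 5 min (a higher number here means a weaker inhibitor, a lower number a stronger inhibitor), compound 3 gives > 2000000 nM, which is a limit of the assay rather than a number. Compound 1 `O=c1cc(/C=N\c2ccc(O)cc2)c2ccc(OCc3ccccc3)cc2o1`, with a 4-hydroxyphenyl group in that place, gives 525000 nM in this assay. Among the measured compounds shown here, the step of an at least 3.8-fold higher number from compound 1 to compound 3 (0.58 log units; beyond the scatter) is the only measured change at this position. Compound 2 `O=c1cc(/C=N\O)c2c(OCc3ccccc3)cc(OCc3ccccc3)cc2o1`, an oxime carrying two benzyloxy groups, gives > 2000000 nM in this assay, again a limit. Both limits are the same: the limit of > 2000000 nM in this assay, at which 2 of the 3 values shown sit.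

Compound 4 `O=c1cc(/C=N\O)c2ccc(OCc3ccccc3)cc2o1` differs from compound 3 by hydroxy in place of (4-nitrophenyl)amino on a double-bonded nitrogen. For the measured compounds named here, no measured step covers this exact exchange; the one step at this position, an at least 3.8-fold higher number from compound 1 to compound 3 (0.58 log units; beyond the scatter), ended at the limit, and compound 2 shows an oxime on a close relative also at the limit. The expected step is therefore a number no higher from compound 3 to compound 4 (the limit leaves the size open), nothing beyond the scatter. The value of compound 4 in this assay is estimated at 2000000 nM, within 600000 nM to 5000000 nM.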

Compound 4, half-maximal inhibitory concentration: > 2000000 nM
Compound 4: no number, only a limit (the forecaster's own chance of this, stated with the estimate: 70%); the middle value sits exactly at the limit.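

In this assay compound 4 gives > 2000000 nM, which is a limit of the assay and not a number. The much smaller hydroxy group thus ends up like (4-nitrophenyl)amino, with an at least 3.8-fold higher number from compound 1 to compound 4 (0.58 log units; beyond the scatter), and the oxime stays at the limit with or without the second benzyloxy group. The steps to compound 4 from compound 3 and from compound 2 cannot be read, because both ends of each step are limits: the limit of > 2000000 nM in this assay, at which 3 of the 4 values shown sit.

As far as these compounds go, whether compound 2, compound 3 and compound 4 differ from one another at all remains open. Also open, from the compounds shown here alone, is whether a different group on this double-bonded nitrogen, such as a 4-aminophenyl group or a phenyl ring carrying a carboxylic acid, would give a readable number, and how that number would compare with compound 1.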